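This account rests on a few compounds, and the source may have more. Where it says the series, first, only, none or still open, it means among the compounds named here.

Measured so far:
compound 1, `Oc1cccc(-c2cc(-c3ccc(Cl)cc3)nc(-c3cccs3)c2)c1`: 11800 nM
compound 2, `Oc1cccc(-c2cc(-c3ccc(Cl)cc3)nc(-c3cccnc3)c2)c1`: 39500 nM
compound 3, `Oc1ccc(-c2cc(-c3ccc(Cl)cc3)nc(-c3ccsc3)c2)cc1`: 4860 nM

In an ADME assay on HEK293 cells (Homo sapiens) for cytotoxicity, read by CCK-8 assay and cell counting, with a stated time of 2 days (a lower number here means a stronger inhibitor, a higher number a weaker inhibitor), compound 3 gives the lowest of the three numbers. Its nearest neighbour on the numbers is compound 1, and compound 2 stands furthest from it, at the highest number of the set.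

The step now considered leads from compound 3 to compound 4, `Oc1cccc(-c2cc(-c3ccc(Cl)cc3)nc(-c3ccsc3)c2)c1`: 3-hydroxyphenyl in place of 4-hydroxyphenyl on an aromatic carbon. For the measured compounds named here, the only measured step with a single change, a 3.3-fold higher number from compound 1 to compound 2 (0.52 log units; beyond the scatter), concerns the group opposite the ring nitrogen and not the hydroxyphenyl group, so it does not bear directly on this change. Compound 1 carries a 3-hydroxyphenyl group like compound 4 but a thiophen-2-yl group, so the values of compound 1 and compound 3 show only the combined effect of two changes and cannot be separated. Nothing measured therefore speaks to the move of the hydroxyl on its own.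

Without a bearing step, compound 4 is expected to land between compound 3 and compound 1, and the estimate for compound 4 in this assay is 7500 nM, with a range from 3000 nM to 20000 nM. This estimate means a step of a 1.5-fold higher number from compound 3 to compound 4 (0.19 log units; within the scatter), which is expected to stay near the scatter.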

Compound 4, half-maximal inhibitory concentration: 11200 nM
For compound 4 the middle estimate is 1.5-fold (0.17 log units) below the measured one; measured number inside the range.
By their numbers in this assay, from the lowest: compound 3; then compounds 4 and 1 (each within the scatter of the next); then compound 2.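

In this assay, the move of the hydroxyl can now be read on its own, with thiophen-3-yl held constant, and 3-hydroxyphenyl in place of 4-hydroxyphenyl gives a modest step beyond the scatter (a 2.3-fold higher number from compound 3 to compound 4 (0.36 log units; beyond the scatter)), so the hydroxyl's placement on this ring does register at this position. With 3-hydroxyphenyl held constant, compound 4 also shows that thiophen-3-yl and thiophen-2-yl cannot be told apart (a 1.1-fold lower number from compound 1 to compound 4 (0.02 log units; within the scatter)), whereas thiophen-3-yl and pyridin-3-yl can (a 3.5-fold lower number from compound 2 to compound 4 (0.55 log units; beyond the scatter)), and that step is of much the same size as the one from thiophen-2-yl to pyridin-3-yl (a 3.3-fold higher number from compound 1 to compound 2 (0.52 log units; beyond the scatter)). Nothing available gives a reason for any of these differences.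

Among the compounds shown, 4-hydroxyphenyl occurs only with thiophen-3-yl, so it remains open whether the hydroxyl move would read the same alongside thiophen-2-yl or pyridin-3-yl. They also leave open how this assay would respond to an amine, a carboxylic acid or a methoxy group standing in place of the hydroxyl.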